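Iodo for fluoro on the 2-fluorophenyl ring

A few compounds are considered here, and "the series" means these few. Any claim that something is new, unique, unknown or untested is made for them only; others in the source may bear on it.

Measured compounds:
Compound 1 `O=C(Nc1cccc(C(=O)O)c1)N[C@H]1CC[C@H](Oc2ccc(F)cc2)CC1` — in a functional assay on CRL2813 cells (Homo sapiens) for cytotoxicity, read by sulforhodamine B assay, with a stated time of 5 days (on this read-out higher numbers stand for weaker inhibition and lower numbers for stronger inhibition), compound 1 returns only the limit > 20000 nM.
Compound 2 `O=C(Nc1cccc(F)c1)N[C@H]1CC[C@H](Oc2ccc(F)cc2)CC1` — in this assay compound 2 gives 8300 nM.
Compound 3 `O=C(Nc1ccccc1F)N[C@H]1CC[C@H](Oc2ccc(F)cc2)CC1` — in this assay compound 3 gives 17500 nM.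

Of the two numbers, compound 3 holds the higher one; the step of a 2.1-fold higher number from compound 2 to compound 3 (0.32 log units; beyond the scatter) is beyond the scatter, so compound 3 is the weaker of the two. Compound 1 sits at a limit (the limit of > 20000 nM in this assay, at which 1 of the 3 values shown sits), and the steps of an at least 2.4-fold lower number from compound 1 to compound 2 (0.38 log units; beyond the scatter) and an at least 1.1-fold lower number from compound 1 to compound 3 (0.05 log units; that floor lies within the scatter) are floors only.

Compound 4 `O=C(Nc1ccccc1I)N[C@H]1CC[C@H](Oc2ccc(F)cc2)CC1` differs from compound 3 in one place: iodo in place of fluoro on an aromatic carbon. None of the measured steps exchanges one halogen for another on that ring; the steps shown change fluoro for carboxy, or move a fluoro from one position to another, and the only one beyond the scatter concerns the position, not the atom. Within the data shown here, no measured step therefore bears directly on iodo in place of fluoro, and with the weak numbers around compound 3 the expectation is a change not beyond the scatter, with a real chance of a limit. The estimate for compound 4 in this assay is 15000 nM, between 5000 nM and 40000 nM, which amounts to an expected step of a 1.2-fold lower number from compound 3 to compound 4 (0.07 log units; within the scatter).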

Compound 4, half-maximal inhibitory concentration: > 20000 nM
Compound 4 ended at the assay's limit; the forecaster's own chance of this, stated with the estimate: 30%; middle value at least 1.3-fold (0.12 log units) from the limit.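

In this assay compound 4 gives > 20000 nM, which is a limit of the assay and not a number. Iodo in place of fluoro, on an aromatic carbon ortho to a large group, is the only exchange of one halogen for another shown, and it gives an at least 1.1-fold higher number from compound 3 to compound 4 (0.05 log units; that floor lies within the scatter), a floor within the scatter that does not separate the two halogens at this position, while the change of both group and position gives an at least 2.4-fold higher number from compound 2 to compound 4 (0.38 log units; beyond the scatter), a floor beyond the scatter that keeps the 3-fluorophenyl compound as the only one of the four with a reading well below the limit. The step from compound 1 to compound 4 cannot be read, and the series now presses against the top of the assay's range: the limit of > 20000 nM in this assay, at which 2 of the 4 values shown sit.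

As far as these compounds go, whether chloro, bromo or an amine in place of the iodo would bring the number clear of the limit stays open, so the true size of the halogen exchange at this position is unknown. Also open, from the compounds shown here alone, is whether a methoxy group or a nitrile on the same ring would follow the 3-fluorophenyl or the 2-fluorophenyl compound.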